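Removing the Acetyl Group from Compound 3

The compounds below may be only part of what the source reports. "The series", "measured", "known", "first", "only" and "open" are said of these compounds alone.

Of the compounds shown here, three sharing one core have been measured in an assay on cells (strain Sprague-Dawley) for inhibition of Polyunsaturated fatty acid 5-lipoxygenase (Rattus norvegicus), with a stated time of 30 min; a lower number here means a stronger inhibitor, a higher number a weaker inhibitor. Compound 1 `CS(=O)(=O)c1ccc(-c2nc(SCCOC(=O)/C=C/c3ccc(O)c(O)c3)nn2-c2ccccc2)cc1` gives 850 nM, compound 2 `COc1cc(/C=C/C(=O)OCCSc2nc(-c3ccc(S(C)(=O)=O)cc3)n(-c3ccc(C)cc3)n2)ccc1OC(C)=O` gives 980 nM, and compound 3 `COc1cc(/C=C/C(=O)OCCSc2nc(-c3ccc(S(C)(=O)=O)cc3)n(-c3ccccc3)n2)ccc1OC(C)=O` gives 960 nM. On these numbers compound 3 stands second highest of the three, with compound 2 nearest and compound 1 furthest, both gaps within the scatter. The two measured steps say the same: a 1.1-fold higher number from compound 1 to compound 3 (0.05 log units; within the scatter), and a 1.0-fold lower number from compound 2 to compound 3 (0.01 log units; within the scatter).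

Compound 4 `COc1cc(/C=C/C(=O)OCCSc2nc(-c3ccc(S(C)(=O)=O)cc3)n(-c3ccccc3)n2)ccc1O` differs from compound 3 by hydrogen in place of acetyl on an oxygen on an aromatic ring. Of the measured steps, only a 1.1-fold higher number from compound 1 to compound 3 (0.05 log units; within the scatter) bears on this part of the molecule, exchanging the whole 4-acetoxy-3-methoxyphenyl for 3,4-dihydroxyphenyl, and even that larger exchange stayed within the scatter. The step from compound 2 to compound 3 concerns a different ring and gives no further guidance. Compound 4 is therefore expected to show a step of a 1.1-fold lower number from compound 3 to compound 4 (0.03 log units; within the scatter), none beyond the scatter. In this assay compound 4 is estimated at 900 nM, within a range from 450 nM to 1800 nM.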

Compound 4, half-maximal inhibitory concentration: 840 nM
For compound 4 the middle estimate is 1.1-fold (0.03 log units) above the measured one; measured number inside the range.
By their numbers in this assay, from the lowest: compounds 4, 1, 3 and 2 (each within the scatter of the next).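

In this assay, among these compounds, taking off the acetyl alone gives a 1.1-fold lower number from compound 3 to compound 4 (0.06 log units; within the scatter), so a free hydroxy serves as well as the acetoxy at this position, a single change that the earlier compounds did not isolate. Compound 4 also isolates the methyl on the neighbouring oxygen from the larger exchange seen earlier, with a 1.0-fold lower number from compound 1 to compound 4 (0.01 log units; within the scatter), so each of the two changes, read singly, stays within the scatter. No measurement on these compounds offers a reason for this insensitivity.

The compounds shown all keep an oxygen on this aromatic ring, so it remains open whether that oxygen matters at all. An amine or a carboxylic acid in place of the hydroxy, or a longer acyl chain in place of the acetyl, could still move the number beyond the scatter.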